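The source may report more compounds than this note shows. Statements on the series, on what has been measured and on what is new or still open speak of the compounds shown alone.

Measured so far in a functional assay on CCRF-CEM cells (Homo sapiens) for antiproliferative activity, read by MTT assay, with a stated time of 3 days; on this read-out higher numbers stand for weaker inhibition and lower numbers for stronger inhibition:

- compound 1 `CCCCC#Cc1cn(C/C=C\CN2C(=O)c3ccccc3C2=O)c(=O)[nH]c1=O` gives 100000 nM
- compound 2 `O=C1c2ccccc2C(=O)N1C/C=C\Cn1cc(C#CCCc2ccccc2)c(=O)[nH]c1=O` gives 168000 nM
- compound 3 `O=C1c2ccccc2C(=O)N1C/C=C/Cn1cc(C#CCCc2ccccc2)c(=O)[nH]c1=O` gives 38000 nM

Compounds 2 and 3 share one core; the difference between them is the two compounds have the same atoms and bonds and differ only in configuration as drawn: 1 of 1 stereo elements differ; a double bond is drawn Z in compound 2 and E in compound 3. The step of a 4.4-fold lower number from compound 2 to compound 3 (0.65 log units; beyond the scatter) can be tied only to the fact that compounds 2 and 3 differ only in the configuration as drawn. Going by the values given here, compound 3 stands with the lowest number of the three so far.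

From compound 2 to compound 1 the change is ethyl in place of phenyl on a saturated chain carbon, two bonds along the chain from a triple-bonded carbon, and it gave a 1.7-fold lower number from compound 2 to compound 1 (0.23 log units; within the scatter).

Compound 4 `CCCCC#Cc1cn(C/C=C/CN2C(=O)c3ccccc3C2=O)c(=O)[nH]c1=O` remains to be measured in this assay. Among the compounds with values here, it differs from compound 3 by ethyl in place of phenyl on a saturated chain carbon, two bonds along the chain from a triple-bonded carbon, the same change at the same place as the one from compound 2 to compound 1.

The step is expected to be of similar size, a 1.5-fold lower number from compound 3 to compound 4 (0.18 log units; within the scatter), because the earlier instance of this change gave a 1.7-fold lower number from compound 2 to compound 1 (0.23 log units; within the scatter), a step within the scatter. On that basis compound 4 is estimated at 25000 nM. The plausible range for compound 4 is estimated to run from 8000 nM to 80000 nM.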

Compound 4, half-maximal inhibitory concentration: 192000 nM
The estimate for compound 4 lay 7.7-fold (0.89 log units) below the measured number; measured number outside the range, above it.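

In this assay, ethyl in place of phenyl does not carry over unchanged from one core to the other: the same change on two cores in this assay, a 1.7-fold lower number (0.23 log units; within the scatter) from compound 2 to compound 1 and a 5.1-fold higher number (0.70 log units; beyond the scatter) from compound 3 to compound 4, 8.5-fold (0.93 log units) apart, beyond the scatter of two such steps. On the core with the double bond drawn E the change gives a 5.1-fold higher number from compound 3 to compound 4 (0.70 log units; beyond the scatter), while for the hex-1-yn-1-yl compounds the switch of configuration gives only a 1.9-fold higher number from compound 1 to compound 4 (0.28 log units; within the scatter), a step within the scatter, unlike the step with the 4-phenylbut-1-yn-1-yl group, a 4.4-fold lower number from compound 2 to compound 3 (0.65 log units; beyond the scatter): the fact that compounds 1 and 4 differ only in the configuration as drawn. So the outcome of this change depends on the configuration drawn in these two pairs, but two pairs give no reason for the gap and no rule for any further core.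

Open, as far as these compounds go, is whether the step on the E core belongs to the loss of the phenyl ring or to the shorter chain end, which a longer chain or a benzyl-type group in the same place could separate. Also open, from the compounds shown here alone, is whether an amine or a carboxylic acid at the end of the alkyne chain would follow the E or the Z pattern.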